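This account rests on a few compounds, and the source may have more. Where it says the series, first, only, none or still open, it means among the compounds named here.

In a functional assay on NCI-H460 cells (Homo sapiens) for cytotoxicity, read by MTT assay, with a stated time of 72 h (a higher number here means a weaker inhibitor, a lower number a stronger inhibitor), compound 1 `O=C(c1ccc(F)cc1)c1cccc(/C=c2\[nH]c(=O)/c(=C/c3nc[nH]c3C3CC3)[nH]c2=O)c1` gives 2.8 nM, compound 2 `Cc1[nH]cnc1/C=c1\[nH]c(=O)/c(=C/c2cccc(C(=O)c3ccc(F)cc3)c2)[nH]c1=O` gives 15.9 nM and compound 3 `Cc1ccc(/C=c2\[nH]c(=O)/c(=C/c3cccc(Oc4ccc(F)cc4)c3)[nH]c2=O)o1` gives 30 nM. Compound 3 thus lies within the scatter of compound 2 and clearly above compound 1. Compound 4 `Cc1ccc(/C=c2\[nH]c(=O)/c(=C/c3cccc(C(=O)c4ccc(F)cc4)c3)[nH]c2=O)o1` carries (4-fluorophenyl)carbonyl in place of 4-fluorophenoxy on an aromatic carbon. Among the compounds with values here, the only measured step, a 5.7-fold higher number from compound 1 to compound 2 (0.75 log units; beyond the scatter), concerns another place and does not test this exchange. The nearest guide is compound 2, which carries the same (4-fluorophenyl)carbonyl and gives 15.9 nM, though the rest of its structure differs. No change beyond the scatter is therefore expected in this assay. The expected step is a 1.5-fold lower number from compound 3 to compound 4 (0.18 log units; within the scatter). Compound 4 is estimated at 20 nM, within an expected range of 7 nM to 60 nM.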

Compound 4, half-maximal inhibitory concentration: 5.3 nM
Compound 4: the middle estimate sits 3.8-fold (0.58 log units) above what was measured, outside the stated range (below it).
By their numbers in this assay, from the lowest: compounds 1 and 4 (each within the scatter of the next); then compounds 2 and 3 (each within the scatter of the next).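

In this assay, the exchange on an aromatic carbon meta to a large group is not neutral: (4-fluorophenyl)carbonyl in place of 4-fluorophenoxy gives a 5.7-fold lower number from compound 3 to compound 4 (0.75 log units; beyond the scatter) and so lies beyond the scatter. With (4-fluorophenyl)carbonyl held, 5-methylfuran-2-yl in place of 5-methyl-1H-imidazol-4-yl gives a 3.0-fold lower number from compound 2 to compound 4 (0.48 log units; beyond the scatter) and also lies beyond the scatter, whereas in place of 5-cyclopropyl-1H-imidazol-4-yl it gives a 1.9-fold higher number from compound 1 to compound 4 (0.28 log units; within the scatter) and stays within the scatter. Whether an amine or a methylene in place of the carbonyl link would hold this number remains open, and nothing available here accounts for these steps.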